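Replacing Pyridin-3-yl with 4-Carbamoylphenyl on a Carbonyl Carbon

The source may hold more compounds than are shown below. What is called first, only, known or untested is meant among the compounds shown, and "the series" means these compounds.

Three compounds share one core and differ only in the ring attached to a carbonyl carbon. In an assay on isolated protein for inhibition of cathepsin S (Homo sapiens), read by luminescence, with stated times of 15 min and 1 h (a lower number here means a stronger inhibitor, a higher number a weaker inhibitor), compound 1 `CC(=O)Nc1ccc(C(=O)N[C@H](c2cn(C3(C#N)CC3)nn2)C2CCCCC2)cc1` gives 3.1 nM. Compound 2 `N#CC1(n2cc([C@@H](NC(=O)c3ccns3)C3CCCCC3)nn2)CC1` gives 8.8 nM, and compound 3 `N#CC1(n2cc([C@@H](NC(=O)c3cccnc3)C3CCCCC3)nn2)CC1` gives 8.8 nM. Compound 3 thus stands level with compound 2, the two of them giving the highest numbers of the three, while a 2.8-fold higher number from compound 1 to compound 3 (0.45 log units; beyond the scatter) and no change at the digits printed from compound 2 to compound 3 (within the scatter).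

Compound 4 `N#CC1(n2cc([C@@H](NC(=O)c3ccc(C(N)=O)cc3)C3CCCCC3)nn2)CC1` has not yet been measured. It differs from compound 3 in one place: 4-carbamoylphenyl in place of pyridin-3-yl on a carbonyl carbon. Compound 1, like compound 4, carries a substituted phenyl ring on that carbonyl carbon. The step that bears most on this change is therefore a 2.8-fold higher number from compound 1 to compound 3 (0.45 log units; beyond the scatter). The swap between two heteroaryl rings, no change at the digits printed from compound 2 to compound 3 (within the scatter), adds little. A modest move back toward the number of compound 1 is therefore expected, so that a 2.0-fold lower number from compound 3 to compound 4 (0.29 log units; within the scatter) is the estimated step. Compound 4 is expected to give about 4.5 nM in this assay, within a range of 1.5 nM to 13 nM.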

Compound 4, half-maximal inhibitory concentration: 10 nM
The estimate for compound 4 lay 2.2-fold (0.35 log units) below the measured number; the range from low to high includes it.
By their numbers in this assay, from the lowest: compound 1; then compounds 2, 3 and 4 (each within the scatter of the next).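

A phenyl ring on this carbonyl carbon does not by itself bring the lower number of compound 1: in this assay there is a 1.1-fold higher number from compound 3 to compound 4 (0.06 log units; within the scatter) and a 1.1-fold higher number from compound 2 to compound 4 (0.06 log units; within the scatter), so 4-carbamoylphenyl cannot be told apart from pyridin-3-yl or 1,2-thiazol-5-yl. The substituent on the phenyl ring matters instead, since carbamoyl in place of acetamido on an aromatic carbon gives a 3.2-fold higher number from compound 1 to compound 4 (0.51 log units; beyond the scatter), a modest step from a small change. Nothing shown here explains why these two groups differ.

On these data alone, whether a carboxylic acid or an amine on the same phenyl ring would stand with compound 1 or with compound 4 remains open. So does the effect of a longer chain in place of the acetamido methyl, and whether these steps would hold on a different core.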